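The source may report more compounds than this note shows. Statements on the series, on what has been measured and on what is new or still open speak of the compounds shown alone.

Measured compounds:
Compound 1, `COc1ccccc1-c1cn(C[C@H](O)[C@H]2OC(=O)C(OCc3ccccc3)=C2OCc2ccccc2)nn1` — in a functional assay on SW-620 cells (Homo sapiens) for antiproliferative activity, read by MTT assay, with a stated time of 72 h (a higher number here means a weaker inhibitor, a lower number a stronger inhibitor), compound 1 gives a limit, > 100000 nM.
Compound 2, `O=C1O[C@H]([C@@H](O)Cn2cc(CCCCl)nn2)C(OCc2ccccc2)=C1OCc1ccccc1` — in this assay compound 2 gives 68500 nM.
Compound 3, `C[Si](C)(C)c1cn(C[C@H](O)[C@H]2OC(=O)C(OCc3ccccc3)=C2OCc2ccccc2)nn1` — in this assay compound 3 gives 56000 nM.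

Compound 3 stands beside compound 2, the pair separated only by a 1.2-fold lower number from compound 2 to compound 3 (0.09 log units; within the scatter), which is within the scatter. Compound 1 reports only a limit, (the limit of > 100000 nM in this assay, at which 1 of the 3 values shown sits), so its gap to compound 3, an at least 1.7-fold lower number from compound 1 to compound 3 (0.25 log units; that floor lies within the scatter), is a floor that itself lies within the scatter, and the same holds for an at least 1.4-fold lower number from compound 1 to compound 2 (0.16 log units; that floor lies within the scatter).

Compound 4, `Cc1ccc(S(=O)(=O)NCc2cn(C[C@H](O)[C@H]3OC(=O)C(OCc4ccccc4)=C3OCc3ccccc3)nn2)cc1`, differs from compound 3 by a group of 12 heavy atoms (8 carbon, 1 nitrogen, 2 oxygen, 1 sulfur; one six-membered aromatic ring of carbon only) in place of a group of 4 heavy atoms (3 carbon, 1 silicon; no ring), on an aromatic carbon. The group that enters carries a six-membered aromatic ring of carbon only, as the 2-methoxyphenyl of compound 1 does, and compound 1 gave a limit. The three measured steps at this position all fall within the scatter or sit at a floor inside it, so no step beyond the scatter is expected in this assay; if anything, the direction points toward a higher number, as with compound 1.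

Compound 4 is therefore expected to give about 80000 nM, estimated to lie between 30000 nM and 200000 nM. That expectation means a step of a 1.4-fold higher number from compound 3 to compound 4 (0.15 log units; within the scatter).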

Compound 4, half-maximal inhibitory concentration: 45800 nM
The estimate for compound 4 lay 1.7-fold (0.24 log units) above the measured number; measured number inside the range.
By their numbers in this assay, from the lowest: compounds 4, 3 and 2 (each within the scatter of the next). At a limit, above all of these: compound 1.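

In this assay, this position on the aromatic carbon of the five-membered ring accepts the much larger (((4-methylphenyl)sulfonyl)amino)methyl group in place of the silicon-bearing group with no step beyond the scatter: the exchange gives a 1.2-fold lower number from compound 3 to compound 4 (0.09 log units; within the scatter) and the comparison with the 3-chloropropyl compound gives a 1.5-fold lower number from compound 2 to compound 4 (0.17 log units; within the scatter). Among these compounds, the entering group carries a six-membered aromatic ring of carbon only, as the 2-methoxyphenyl does, so such a ring at this position does not by itself go with the weakest reading, and the exchange of these two groups gives an at least 2.1-fold lower number from compound 1 to compound 4 (0.33 log units; beyond the scatter), the first step at this position whose floor lies beyond the scatter. As far as these compounds go, the size of that step stays unknown, since the value of compound 1 is only a limit: the limit of > 100000 nM in this assay, at which 1 of the 4 values shown sits.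

The compounds shown leave open whether any group here can move the number clearly away from the level shared by compounds 2, 3 and 4, for example an amine, a carboxylic acid or a longer chain. They also leave open whether the sulfonyl amino link or the 4-methylphenyl end of the new group matters at all, as a plain phenylsulfonyl or an amide link in its place would test.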